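The compounds below may be only part of what the source reports. "The series", "measured", "known", "first", "only" and "open" are said of these compounds alone.

Measured compounds:

- compound 1, `CC(=O)OCCS(=O)(=O)c1ccc(S(N)(=O)=O)s1`, giving 880 ug/mL in a physicochemical assay for solubility, at pH 7.4; on this read-out higher numbers stand for higher solubility and lower numbers for lower solubility
- compound 2, `CC(=O)OCCCS(=O)(=O)c1ccc(S(N)(=O)=O)s1`, giving 920 ug/mL in this assay
- compound 3, `CC(=O)OCCCc1ccc(S(N)(=O)=O)cc1`, giving 1600 ug/mL in this assay

Compound 1 and compound 2 share a core and differ in one place only: acetoxymethyl in place of acetoxy on a saturated chain carbon, two bonds along the chain from a sulfonyl sulfur. The step that this change made is a 1.0-fold higher number from compound 1 to compound 2 (0.02 log units; within the scatter), so the two numbers lie within the scatter of each other and no order between them is claimed.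

Compound 3 carries a different core; the difference between the core of compound 3 and the core of compound 1 is not broken down here. The values of compound 3 and compound 2, and of compound 3 and compound 1, lie within the scatter of each other, so no order among the three measured compounds is claimed.

Compound 4, `CC(=O)OCCCCc1ccc(S(N)(=O)=O)cc1`, has not yet been measured in this assay. It differs from compound 3 by acetoxymethyl in place of acetoxy on a saturated chain carbon, three bonds along the chain from an aromatic carbon. For the measured compounds named here, this is the same kind of change as the one from compound 1 to compound 2, but the place is not the same: there it sits two bonds along the chain from a sulfonyl sulfur, here three bonds along the chain from an aromatic carbon, and the cores differ. For compound 4 a step of a 1.1-fold lower number from compound 3 to compound 4 (0.03 log units; within the scatter) is expected, because the same kind of change gave a 1.0-fold higher number from compound 1 to compound 2 (0.02 log units; within the scatter). The expected value for compound 4 is 1500 ug/mL, with the range 800 ug/mL to 2800 ug/mL; this estimate rests on one measured step only and on a different core, so the range is kept wide.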

Compound 4, solubility: 800 ug/mL
Estimate against measurement, compound 4: 1.9-fold (0.27 log units) above; measured number inside the range.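

In this assay acetoxymethyl in place of acetoxy gives a 2.0-fold lower number from compound 3 to compound 4 (0.30 log units; within the scatter) and, on the other core, a 1.0-fold higher number from compound 1 to compound 2 (0.02 log units; within the scatter) and so on both cores the pair lies within the scatter, with no order claimed inside either pair. As far as these two pairs go, the change carried from one core to the other has produced no step beyond the scatter, but this does not show that the change is without consequence on this series in general, since the evidence is two pairs only, and the place differs along with the core: two bonds along the chain from a sulfonyl sulfur in one pair, three bonds along the chain from an aromatic carbon in the other, so the part played by core and by place cannot be told apart. Nothing at hand bears on the reason for either number.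

The compounds shown leave open whether a chain longer than the 2-acetoxyethyl group of compound 4 would give a step beyond the scatter on either core. They also leave open how a carboxylic acid or an amine in place of acetoxy would read in this assay on these cores.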